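Swapping the amide aryl group: from biphenyl to dimethylphenyl

A few compounds are considered here, and "the series" means these few. Any claim that something is new, unique, unknown or untested is made for them only; others in the source may bear on it.

Compound 1 `Cc1ccc(Nc2ncc3c(n2)N(C)C(=O)N(c2cc(NC(=O)c4cccc(C(F)(F)F)c4)ccc2C)C3)cc1N(C)C` in an ADME assay on BaF3 cells (Mus musculus) for antiproliferative activity, read by CellTiter-Glo and CCK-8 assay, with a stated time of 72 h (a lower number here means a stronger inhibitor of growth, a higher number a weaker inhibitor of growth), gives > 10000 nM, which is a limit of the assay.
Compound 2 `Cc1ccc(Nc2ncc3c(n2)N(C)C(=O)N(c2cc(NC(=O)c4cccc(C(F)(F)F)c4)ccc2C)C3)cc1N` gives 440 nM.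
Compound 3 `Cc1ccc(Nc2ncc3c(n2)N(C)C(=O)N(c2cc(NC(=O)c4cccc(-c5ccccc5)c4)ccc2C)C3)cc1N` gives > 10000 nM, again only a limit, as noted in the limit of > 10000 nM in this assay, at which 2 of the 3 values shown sit.

Compound 3 thus stands at the limit, with no number of its own. Compound 4 `Cc1cc(C)cc(C(=O)Nc2ccc(C)c(N3Cc4cnc(Nc5ccc(C)c(N)c5)nc4N(C)C3=O)c2)c1` differs from it by 3,5-dimethylphenyl in place of 3-phenylphenyl on a carbonyl carbon. The step of an at least 22-fold lower number from compound 1 to compound 2 (1.35 log units; beyond the scatter) concerns another part of the molecule and does not bear on this change. The step of an at least 22-fold higher number from compound 2 to compound 3 (1.35 log units; beyond the scatter) acts on the same carbonyl-attached group and shows that the trifluoromethyl-bearing ring gives a far lower number than the biphenyl. A smaller dimethyl-bearing ring is expected to move back toward that, giving an at least 5.0-fold lower number from compound 3 to compound 4 (0.69 log units; beyond the scatter). Compound 4 is therefore estimated at 2000 nM, between 300 nM and 10000 nM.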

Compound 4, concentration for 50% growth inhibition: > 10000 nM
Compound 4 was reported as a limit (the forecaster's own chance of this, stated with the estimate: 30%); middle value at least 5.0-fold (0.69 log units) from the limit.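

Replacing the 3-(trifluoromethyl)phenyl group on the carbonyl carbon with 3,5-dimethylphenyl gives an at least 22-fold higher number from compound 2 to compound 4 (1.35 log units; beyond the scatter). So the loss seen with 3-phenylphenyl does not require that group's second aromatic ring: a single-ring group with two methyls also fails to give a measured number. The change from compound 3 to compound 4 cannot be read, as each compound's value is only a limit: the limit of > 10000 nM in this assay, at which 3 of the 4 values shown sit.

Still open, going by these compounds, is whether a phenyl ring carrying a chlorine or a nitrile, or a pyridine ring, would give a measured number at this carbonyl carbon.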